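The source may hold more compounds than are shown below. What is called first, only, known or untested is meant among the compounds shown, and "the series" means these compounds.

Measured compounds:
compound 1, `Cc1ccc(S(=O)(=O)Nc2ccnc(Nc3ccc(C#N)cc3)c2)cc1`, 14000 nM
compound 2, `N#Cc1ccc(Nc2cc(NS(=O)(=O)c3ccc(C#N)cc3)ccn2)cc1`, 93400 nM
compound 3, `Cc1ccc(S(=O)(=O)Nc2ccnc(Nc3ccc(C#N)cc3)n2)cc1`, 130000 nM

These three compounds were tested in an ADME assay on MT4 cells (Homo sapiens) for cytotoxicity, read by MTT assay, with a stated time of 5 days; on this read-out lower numbers stand for higher toxicity in this test and higher numbers for lower toxicity in this test. Compound 1 gives 14000 nM and compound 2 gives 93400 nM, so that the change cyano in place of methyl on an aromatic carbon produced a 6.7-fold higher number from compound 1 to compound 2 (0.82 log units; beyond the scatter). Compound 3, which carries a different core, gives 130000 nM; how its core differs from that of compound 1 is not broken down here. Its number and that of compound 2 lie within the scatter of each other.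

Compound 4, `N#Cc1ccc(Nc2nccc(NS(=O)(=O)c3ccc(C#N)cc3)n2)cc1`, is not yet measured. It differs from compound 3 by cyano in place of methyl on an aromatic carbon, the same change that was made from compound 1 to compound 2 and at the same place. Since that earlier change produced a 6.7-fold higher number from compound 1 to compound 2 (0.82 log units; beyond the scatter), a step of the same direction is expected from compound 3 to compound 4 in this assay, though, because compound 3 already gives 130000 nM, a smaller step is expected here, namely a 1.9-fold higher number from compound 3 to compound 4 (0.28 log units; within the scatter). Compound 4 is therefore estimated at 250000 nM, between 100000 nM and 800000 nM.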

Compound 4, half-maximal cytotoxic concentration: 159000 nM
The estimate for compound 4 lay 1.6-fold (0.20 log units) above the measured number, and the stated range covers the measured number.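

In this assay, putting 4-cyanophenyl in place of 4-methylphenyl gave a 1.2-fold higher number from compound 3 to compound 4 (0.09 log units; within the scatter), so on the core of compound 3 this change did not move the number beyond the scatter. The size of the step therefore did not carry over from one core to the other: the same change on two cores in this assay, a 6.7-fold higher number (0.82 log units; beyond the scatter) from compound 1 to compound 2 and a 1.2-fold higher number (0.09 log units; within the scatter) from compound 3 to compound 4, 5.5-fold (0.74 log units) apart, beyond the scatter of two such steps. Within the data shown here, this shows that, across these two pairs, the outcome of the change depends on the core it is made on, so a step seen on one core cannot simply be transferred to the other; with only two cores, it does not show which feature of the core matters or how the change would behave on a third core.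

The compounds shown carry only methyl or cyano at this place, so the outcome with chlorine, a methoxy group or an amine there remains open on both cores. Going by these compounds, it also remains open whether any of these groups would differ between the two cores as methyl and cyano do.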